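The source may hold more compounds than are shown below. What is called first, only, known or untested is meant among the compounds shown, and "the series" means these compounds.

Three analogues of one shared core have been measured in an assay on HEK293 cells for positive allosteric modulation of metabotropic glutamate receptor 5 (Homo sapiens), read by FLIPR, with a stated time of 1 h; on this read-out lower numbers stand for an effect already at smaller amounts and higher numbers for an effect only at larger amounts of compound. Compound 1 `O=C1NCCc2nc(C#Cc3cccc(F)c3)sc21` gives 290 nM. Compound 2 `Fc1cccc(C#Cc2nc3c(s2)CN(C2CCOC2)CC3)c1` reaches only the limit of the assay, > 10000 nM. Compound 3 `O=C(C1CCC1)N1CCc2nc(C#Cc3ccccc3)sc2C1` likewise reaches only the assay limit, > 10000 nM, so no number is known for it. Compound 3 thus stands at the limit of > 10000 nM in this assay, at which 2 of the 3 values shown sit. Compound 4 `Cc1nc(C(=O)N2CCc3nc(C#Cc4ccccc4)sc3C2)cs1` differs from compound 3 by 2-methyl-1,3-thiazol-4-yl in place of cyclobutyl on a carbonyl carbon. No measured pair among these compounds shows a step of this kind, so its direction is open; the change is expected to leave the value close to the limit, with a step of an at least 1.2-fold lower number from compound 3 to compound 4 (0.09 log units; that floor lies within the scatter) that may be small or none beyond the scatter. Compound 4 is therefore expected at 8000 nM, within 1500 nM to 30000 nM.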

Compound 4, half-maximal effective concentration: 220 nM
The estimate for compound 4 lay 36-fold (1.56 log units) above the measured number; measured number below the stated range.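

In this assay, the carbonyl substituent proves decisive for the series: 2-methyl-1,3-thiazol-4-yl in place of cyclobutyl gives an at least 45-fold lower number from compound 3 to compound 4 (1.65 log units; beyond the scatter). Among these compounds, this is the first readable step at this place, and it moves a compound from the limit to a measured number. The value of compound 3 is only a limit, so the true step size stays unknown: the limit of > 10000 nM in this assay, at which 2 of the 4 values shown sit.

Which part of the 2-methyl-1,3-thiazol-4-yl group carries the step remains open. A phenyl, a pyridine ring or the same thiazole without its methyl on this carbonyl would separate the ring atoms from the methyl.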